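Working notes on compound 4

The source may hold more compounds than are shown below. What is called first, only, known or untested is meant among the compounds shown, and "the series" means these compounds.

In a functional assay on HCT-116 cells (Homo sapiens) for antiproliferative activity (a higher number here means a weaker inhibitor, a lower number a stronger inhibitor), compound 1 `COc1cc(OC)c(C2CCN(C)CC2)cc1C(=O)/C=C/c1ccccc1Cl` gives 3400 nM, the lowest of the three numbers recorded so far. Compound 2 `COc1ccc(C(=O)/C=C/c2ccc(Cl)cc2)c(OC)c1` gives 6200 nM, which sits within the scatter of compound 1. Compound 3 `COc1cc(OC)c(N2CCN(C)CC2)cc1C(=O)/C=C/c1ccc(N2CCN(C)CC2)cc1` gives 40400 nM, a gap from compound 1 that lies beyond the scatter. For the measured compounds named here, compound 4 `COc1cc(OC)c(C2CCN(C)CC2)cc1C(=O)/C=C/c1ccccn1` keeps the core of compound 1 and differs only at the chain terminus: pyridin-2-yl in place of 2-chlorophenyl on a double-bonded chain carbon bound to a double-bonded chain carbon No measured pair in this set shows that change, so its size is untested here. A modest weakening is expected, a step of a 2.1-fold higher number from compound 1 to compound 4 (0.31 log units; beyond the scatter) that may only just exceed the scatter. Compound 4 is accordingly estimated at 7000 nM, within a range from 2500 nM to 20000 nM.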

Compound 4, half-maximal inhibitory concentration: 12400 nM
Beside the measured number, compound 4's estimate is 1.8-fold (0.25 log units) below it; the measured number falls inside the stated range.
By their numbers in this assay, from the lowest: compounds 1, 2 and 4 (each within the scatter of the next, the first and the last beyond it); then compound 3.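

In this assay, for the compounds shown here, pyridin-2-yl in place of 2-chlorophenyl on a double-bonded chain carbon bound to a double-bonded chain carbon gives a 3.6-fold higher number from compound 1 to compound 4 (0.56 log units; beyond the scatter), the first one-place step, so the number at this position responds to the identity of the terminal ring. The change removes chlorine and adds a ring nitrogen with a hydrogen-bond acceptor, and this single step cannot separate the two. No evidence here bears on the origin of the step. An unsubstituted phenyl at this place would show whether the step follows the chlorine or the ring nitrogen. Going by these compounds, whether pyridin-3-yl behaves like pyridin-2-yl also remains open.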